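A few compounds are considered here, and "the series" means these few. Any claim that something is new, unique, unknown or untested is made for them only; others in the source may bear on it.

In a functional assay on the whole organism (strain Sprague-Dawley) for inhibition, with Rattus norvegicus as the target, with a stated time of 10 min (on this read-out lower numbers stand for an effect already at smaller amounts and higher numbers for an effect only at larger amounts of compound), two compounds of this small series carry numbers. Compound 1 (`Nc1ccccc1-c1ncc(C(=O)O)c(=O)[nH]1`) gives 50 mg/kg and compound 2 (`CCCOc1ccc(OC)cc1-c1ncc(C(=O)O)c(=O)[nH]1`) gives 0.3 mg/kg as a much lower value, which means an effect at a far smaller dose. Compound 3 (`CCOC(=O)c1cnc(-c2ccccc2N)[nH]c1=O`) has only the entry "not determined" (no result reported) in this record, so it holds no place on the scale and offers no number to start from. Compound 4 (`CCOC(=O)c1cnc(-c2ccccc2OC(C)CC)[nH]c1=O`) differs from it by one change (sec-butoxy in place of amino on an aromatic carbon) with sec-butoxy in place of amino on an aromatic carbon. Going by the values given here, no measured step exists between closely related compounds, so neither the size nor the direction of a step from compound 3 in this assay can be stated, and only a loose expectation is possible. Compound 4 is expected to lie within the span of the two measured values, nearer to compound 2 at 0.3 mg/kg than to compound 1 at 50 mg/kg on this dose scale. For compound 4 the estimated dose is 3 mg/kg within an expected range of 0.3 mg/kg to 30 mg/kg in this measurement.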

Compound 4, dose for 50% inhibition: 0.5 mg/kg
Estimate against measurement, compound 4: 6.0-fold (0.78 log units) above, and the stated range covers the measured number.
By their numbers in this assay, from the lowest: compounds 2 and 4 (each within the scatter of the next); then compound 1.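

In this assay, going by these compounds alone, compound 3 has no number, so no step to compound 4 can be read. The compounds shown leave open how sec-butoxy in place of amino on an aromatic carbon shifts the dose. No evidence at hand bears on the result for compound 4.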